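This account rests on a few compounds, and the source may have more. Where it says the series, first, only, none or still open, it means among the compounds named here.

In a functional assay on HeLa cells (Homo sapiens) for cytotoxicity, read by MTT assay (a higher number here means a weaker inhibitor, a lower number a stronger inhibitor), compound 1 `CCCc1nc2c(C)cc(-c3nc4ccccc4n3C)cc2n1S(=O)(=O)c1ccccc1` gives 23800 nM. Compound 2 `CCCc1nc2c(C)cc(-c3nc4ccccc4n3C)cc2n1S(=O)(=O)c1c(C)cc(C)cc1C` gives 21000 nM, and the step of a 1.1-fold lower number from compound 1 to compound 2 (0.05 log units; within the scatter) stays within the scatter. Compound 3 `CCCc1nc2c(C)cc(-c3nc4ccccc4n3C)cc2n1S(=O)(=O)c1cc(Cl)ccc1Cl` reaches only a limit of the assay, > 50000 nM, so its place among the values is known only as the limit of > 50000 nM in this assay, at which 1 of the 3 values shown sits. The steps of an at least 2.1-fold higher number from compound 1 to compound 3 (0.32 log units; beyond the scatter) and an at least 2.3-fold higher number from compound 2 to compound 3 (0.37 log units; beyond the scatter) both run toward a higher number when 2,5-dichlorophenyl enters. Compound 4 `CCCc1nc2c(C)cc(-c3nc4ccccc4n3C)cc2n1S(=O)(=O)c1ccccc1Cl` differs from compound 3 by hydrogen in place of chloro on an aromatic carbon. A move back toward a lower number is therefore expected, of size an at least 1.4-fold lower number from compound 3 to compound 4 (0.15 log units; that floor lies within the scatter), though the limit of compound 3 leaves its extent uncertain. Compound 4 is estimated at 35000 nM, within a range from 15000 nM to 100000 nM.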

Compound 4, half-maximal inhibitory concentration: > 50000 nM
Compound 4: no number, only a limit (the forecaster's own chance of this, stated with the estimate: 40%); at least 1.4-fold (0.15 log units) between middle value and limit.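

In this assay, compound 4 reaches only a limit of the assay, > 50000 nM, so taking away the chloro para to the other chloro brings no measurable return; the step between compound 3 and compound 4 cannot be read. The remaining single chloro on the phenyl is enough for an at least 2.1-fold higher number from compound 1 to compound 4 (0.32 log units; beyond the scatter), and replacing 2,4,6-trimethylphenyl gives an at least 2.3-fold higher number from compound 2 to compound 4 (0.37 log units; beyond the scatter). The values now gather at one limit: the limit of > 50000 nM in this assay, at which 2 of the 4 values shown sit.

On these data alone, whether the second chloro changes anything beyond that limit stays open. So does how a methoxy group or an amine would read at this position.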